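Piperidine replaces diethylamino on the flavone side chain

The compounds below may be only part of what the source reports. "The series", "measured", "known", "first", "only" and "open" are said of these compounds alone.

Measured compounds:
compound 1, `COc1cc2oc(-c3ccccc3)cc(=O)c2c(O)c1OCCCN1CCN(C)CC1`, 31300 nM
compound 2, `COc1cc2oc(-c3ccccc3)cc(=O)c2c(O)c1OCCCCN1CCCC1`, 10600 nM
compound 3, `CCN(CC)CCCCOc1c(OC)cc2oc(-c3ccccc3)cc(=O)c2c1O`, 17400 nM

In a functional assay on BCG823 cells (Homo sapiens) for antiproliferative activity, read by MTT assay, with a stated time of 48 h (on this read-out lower numbers stand for stronger inhibition and higher numbers for weaker inhibition), compound 3 stands second highest of the three numbers. Its nearest neighbour is compound 2, and the step of a 1.6-fold higher number from compound 2 to compound 3 (0.22 log units; within the scatter) lies within the scatter; toward compound 1 the step of a 1.8-fold lower number from compound 1 to compound 3 (0.25 log units; within the scatter) also lies within the scatter, so compound 3 cannot be separated from either measured compound on these numbers.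

Compound 4, `COc1cc2oc(-c3ccccc3)cc(=O)c2c(O)c1OCCCN1CCCCC1`, has not yet been measured. It differs from compound 3 as follows: piperidin-1-yl in place of (diethylamino)methyl on a saturated chain carbon, three bonds along the chain from an oxygen on an aromatic ring. The measured steps that bear on this change are those that swap one amine for another at the end of the side chain. Within the data shown here, the only step beyond the scatter is a 3.0-fold lower number from compound 1 to compound 2 (0.47 log units; beyond the scatter), where a ring amine replaced the 4-methylpiperazin-1-yl group. The most closely related step, a 1.6-fold higher number from compound 2 to compound 3 (0.22 log units; within the scatter), compares a ring amine with the diethylamino group directly and is within the scatter. On that basis compound 4 is expected to show a step of a 1.5-fold lower number from compound 3 to compound 4 (0.16 log units; within the scatter) that stays within the scatter, with at most a slight lean toward a lower number. Compound 4 is therefore estimated at 12000 nM in this assay, within a range from 5000 nM to 30000 nM.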

Compound 4, half-maximal inhibitory concentration: 25300 nM
Beside the measured number, compound 4's estimate is 2.1-fold (0.32 log units) below it; low and high end bracket the measured number.
By their numbers in this assay, from the lowest: compounds 2, 3, 4 and 1 (each within the scatter of the next, the first and the last beyond it).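

In this assay, replacing the open (diethylamino)methyl end with piperidin-1-yl, a swap that keeps the count of heavy atoms, gives a 1.5-fold higher number from compound 3 to compound 4 (0.16 log units; within the scatter), so a ring at this place does not separate compound 4 from compound 3. Among these compounds, a ring amine as such does not secure the lower number seen for compound 2, since a 2.4-fold higher number from compound 2 to compound 4 (0.38 log units; beyond the scatter) is the one new step beyond the scatter, while a 1.2-fold lower number from compound 1 to compound 4 (0.09 log units; within the scatter) leaves compound 4 inseparable from the 4-methylpiperazin-1-yl compound. No measurement is available here that would explain these differences.

Compounds 2 and 3 carry a butyl link to the amine and compound 4 a propyl link, so the compounds shown cannot tell whether the step to compound 2 follows the amine or the chain, and a 4-(piperidin-1-yl)butyl or 3-(pyrrolidin-1-yl)propyl side chain would be needed to pull the two apart. Going by these compounds, how a morpholine at the end of the chain would compare also remains open, as does whether any of these steps would hold on other cell lines.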